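The source may hold more compounds than are shown below. What is called first, only, known or untested is meant among the compounds shown, and "the series" means these compounds.

Measured so far in an assay on striatum for inhibition of 5-hydroxytryptamine receptor 4 (Cavia porcellus), read by radioligand binding; a higher number here means a weaker inhibitor, a lower number a stronger inhibitor:
compound 1 `COc1cc(N)c(Cl)cc1C(=O)NC1CCN(CC2CCN(CCCCN)CC2)CC1` gives 6.47 nM
compound 2 `COc1cc(N)c(Cl)cc1C(=O)NC1CCN(CC2CCN(CC(C)CN)CC2)CC1` gives 14.3 nM
compound 3 `CCCC(N)C(=O)N1CCC(CN2CCC(NC(=O)c3cc(Cl)c(N)cc3OC)CC2)CC1` gives 2.57 nM

Compound 3 stands lowest of the three numbers in this assay, which makes it the strongest inhibitor shown. Its nearest neighbour is compound 1, a 2.5-fold lower number from compound 1 to compound 3 (0.40 log units; beyond the scatter), and the gap to compound 2 is wider, a 5.6-fold lower number from compound 2 to compound 3 (0.75 log units; beyond the scatter). Both steps lie beyond the scatter, so the (1-aminobutyl)carbonyl group marks a clear gain over the two open amine chains.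

Compound 4 `COc1cc(N)c(Cl)cc1C(=O)NC1CCN(CC2CCN(C(=O)CN)CC2)CC1` keeps everything of compound 3 except one group: hydrogen in place of propyl on a saturated chain carbon bound to an amine nitrogen and a carbonyl carbon. Among the compounds with values here, no measured pair shows this change directly. Within the data shown here, the only step that alters a group on a saturated chain carbon bound to an amine nitrogen in a ring is a 2.2-fold higher number from compound 1 to compound 2 (0.34 log units; beyond the scatter), a modest loss, and it concerns a different chain. There is therefore little to lean on; the expectation is that trimming the propyl costs a little while leaving compound 4 among the stronger compounds. For compound 4 the expected outcome is a 1.9-fold higher number from compound 3 to compound 4 (0.29 log units; within the scatter), that is an estimated 5 nM, with a likely range from 1.5 nM to 16 nM.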

Compound 4, half-maximal inhibitory concentration: 9.3 nM
Beside the measured number, compound 4's estimate is 1.9-fold (0.27 log units) below it; measured number inside the range.
By their numbers in this assay, from the lowest: compound 3; then compounds 1, 4 and 2 (each within the scatter of the next, the first and the last beyond it).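

In this assay, within the data shown here, taking the propyl off the saturated chain carbon bound to an amine nitrogen and a carbonyl carbon gives a 3.6-fold higher number from compound 3 to compound 4 (0.56 log units; beyond the scatter), the first direct reading at this position, and it shows that the propyl counts for something here. The carbonyl alone does not account for the advantage of compound 3, since the shorter (aminomethyl)carbonyl group leaves compound 4 level with the open amine chains: the steps are a 1.5-fold lower number from compound 2 to compound 4 (0.19 log units; within the scatter) and a 1.4-fold higher number from compound 1 to compound 4 (0.16 log units; within the scatter), and both stay within the usual scatter. No supporting measurement is available to explain the effect of the propyl.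

The compounds shown leave open how the number changes with the size of the group on this carbon, for example whether a methyl keeps part of the propyl's contribution or whether a longer chain such as pentyl or a ring such as phenyl lowers the number further. They also leave open whether the amine on this carbon is needed, which a hydroxyl in its place could test.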